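The source may hold more compounds than are shown below. What is called first, only, known or untested is meant among the compounds shown, and "the series" means these compounds.

Of the compounds shown here, three built on one shared core have been tested in a functional assay on the whole organism (Pleural cavity) for inhibition, with Rattus norvegicus as the target, at a dose of 25 mg/kg; a lower number here means less inhibition, a higher number more inhibition at the dose given (going by the name of the read-out). Compound 1 `CC1(Cc2ccccc2)C(=O)N(c2ccccc2)c2ncccc21` gives 9%. Compound 2 `CCC1(C)C(=O)N(c2ccccc2)c2ncccc21` gives 36%, and compound 3 `COCCSC1(C)C(=O)N(c2ccccc2)c2ncccc21` gives 26%. Compound 3 thus stands second highest of the three numbers: its gap to compound 2 is within the scatter, a number 10 percentage points lower from compound 2 to compound 3 (within the scatter), whereas compound 1 lies clearly lower, a number 17 percentage points higher from compound 1 to compound 3 (beyond the scatter). The largest step seen so far, a number 27 percentage points higher from compound 1 to compound 2 (beyond the scatter), came from swapping a phenyl for a methyl on the side chain.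

Compound 4 `CCCCC1(C)C(=O)N(c2ccccc2)c2ncccc21` has not yet been measured. It differs from compound 3 in one place: butyl in place of (2-methoxyethyl)sulfanyl on a saturated ring carbon. The step that bears most on it, a number 10 percentage points lower from compound 2 to compound 3 (within the scatter), exchanged a plain carbon chain, ethyl, for the (2-methoxyethyl)sulfanyl group and stayed within the scatter. Returning to a plain carbon chain, now butyl, is therefore expected to change this assay only a little, a number 6 percentage points higher from compound 3 to compound 4 (within the scatter), with a slight lean upward toward compound 2. Compound 4 is estimated to give 32%, in a range from 15% to 50%.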

Compound 4, a percentage reported as inhibition, in the whole organism at one dose (the size of the read-out at that dose, not a potency): 21%
Compound 4: middle estimate off by 11 percentage points, on the high side; low and high end bracket the measured number.
By their numbers in this assay, from the lowest: compound 1; then compounds 4, 3 and 2 (each within the scatter of the next, the first and the last beyond it).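

On this saturated ring carbon, this assay does not separate butyl from (2-methoxyethyl)sulfanyl, a number 5 percentage points lower from compound 3 to compound 4 (within the scatter), so a plain carbon chain and one carrying oxygen and sulfur cannot be told apart here. Chain length on the same carbon does register, a number 15 percentage points lower from compound 2 to compound 4 (beyond the scatter), which means that butyl and ethyl are not interchangeable, although butyl still differs from benzyl, a number 12 percentage points higher from compound 1 to compound 4 (beyond the scatter). Nothing measured here explains why these steps take the sizes they do.

With only ethyl and butyl as plain chains, two compounds cannot show whether the number keeps falling with a longer chain such as hexyl. On these data alone, it also remains open how a chain ending in an amine or a carboxylic acid would behave on this ring carbon.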